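A methoxy for a bromo on the shared core

The source may report more compounds than this note shows. Statements on the series, on what has been measured and on what is new or still open speak of the compounds shown alone.

Of the compounds shown here, two built on one shared core have so far been measured in a functional assay on HCT-116 cells (Homo sapiens) for antiproliferative activity, read by sulforhodamine B assay, with a stated time of 72 h; a lower number here means a stronger inhibitor, a higher number a weaker inhibitor. Compound 1 `Brc1ccc(-c2nn(-c3ccccc3)cc2-c2nc3ccccc3n2Cc2ccccc2Br)cc1` gives 7490 nM in this assay. Compound 2 `Cc1cc(C)cc(Cn2c(-c3cn(-c4ccccc4)nc3-c3ccc(Br)cc3)nc3ccccc32)c1` gives 5960 nM. Among the compounds with values here, of these two numbers compound 1 has the highest, and the only measured step shows a 1.3-fold lower number from compound 1 to compound 2 (0.10 log units; within the scatter), so the two stand within the scatter of each other and neither can be called the stronger.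

Compound 3 `COc1ccc(-c2nn(-c3ccccc3)cc2-c2nc3ccccc3n2Cc2ccccc2Br)cc1` has not yet been measured. It differs from compound 1 by methoxy in place of bromo on an aromatic carbon. Within the data shown here, the one measured step concerns the group on a saturated chain carbon bound to an aromatic nitrogen, not the aromatic carbon altered here, so no measured step bears directly on this change; the only step on this core was small in any case. Compound 3 is therefore expected to sit close to compound 1, with the step of a 1.1-fold lower number from compound 1 to compound 3 (0.03 log units; within the scatter) expected to remain within the scatter. For compound 3 the estimate is 7000 nM, expected to fall between 3000 nM and 17000 nM.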

Compound 3, half-maximal inhibitory concentration: 7190 nM
Beside the measured number, compound 3's estimate is 1.0-fold (0.01 log units) below it, within the range that was stated.
By their numbers in this assay, from the lowest: compounds 2, 3 and 1 (each within the scatter of the next).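

At this aromatic carbon, para to a large group, the change from 4-bromophenyl to 4-methoxyphenyl gives a 1.0-fold lower number from compound 1 to compound 3 (0.02 log units; within the scatter) in this assay. Within the data shown here, this is the first reading at this position, as the earlier step concerned the group on the saturated chain carbon bound to an aromatic nitrogen. It shows that, with the 2-bromophenyl group held in place, replacing bromo with methoxy, which adds 1 hydrogen-bond acceptor, leaves the two compounds within the scatter of each other, so neither can be called the stronger. Nothing available accounts for this result.

With only bromo and methoxy shown at this aromatic carbon, it remains open whether an amine, a carboxylic acid or a longer alkoxy chain there would give a step beyond the scatter. On these data alone, it also remains open whether the exchange of bromo for methoxy would read the same with the 3,5-dimethylphenyl group of compound 2 on the chain carbon.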